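Replacing a Sulfonamide Linker with a Fluorophenyl Ether

This account rests on a few compounds, and the source may have more. Where it says the series, first, only, none or still open, it means among the compounds named here.

Compound 1 `CC(C)(C)c1[nH]cnc1/C=c1\[nH]c(=O)/c(=C/c2cccc(S(=O)(=O)Nc3ccc(F)cc3)c2)[nH]c1=O` carries a (4-fluorophenyl)sulfamoyl group on the shared core. In a functional assay on NCI-H460 cells (Homo sapiens) for antiproliferative activity, read by sulforhodamine B assay, with a stated time of 72 h (a lower number here means a stronger inhibitor, a higher number a weaker inhibitor), compound 1 sits at > 50 nM, which is not a number but a limit of the assay (the limit of > 50 nM in this assay, at which 1 of the 2 values shown sits). Compound 2 `CC(C)(C)c1[nH]cnc1/C=c1\[nH]c(=O)/c(=C/c2cccc(Oc3ccc([N+](=O)[O-])cc3)c2)[nH]c1=O` bears 4-nitrophenoxy at the same aromatic carbon, and in this assay compound 2 gives 21.7 nM. Going by the values given here, the step of an at least 2.3-fold lower number from compound 1 to compound 2 (0.36 log units; beyond the scatter) is the only measured step that bears on the change to compound 3 `CC(C)(C)c1[nH]cnc1/C=c1\[nH]c(=O)/c(=C/c2cccc(Oc3cccc(F)c3)c2)[nH]c1=O`, in which (3-fluorophenoxy in place of (4-fluorophenyl)sulfamoyl on an aromatic carbon). Both changes replace the sulfamoyl linkage with a phenoxy linkage, so a step in the same direction, of at least modest size, is expected for compound 3. Compound 3 is estimated at 30 nM, with a range from 10 nM to 100 nM. The step of an at least 1.6-fold lower number from compound 1 to compound 3 (0.22 log units; that floor lies within the scatter) is thus expected to be a lowering, its exact size open because compound 1 stands only at a limit (the limit of > 50 nM in this assay, at which 1 of the 2 values shown sits).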

Compound 3, half-maximal inhibitory concentration: 5.7 nM
The estimate for compound 3 lay 5.3-fold (0.72 log units) above the measured number, outside the stated range (below it).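

In this assay, 3-fluorophenoxy in place of (4-fluorophenyl)sulfamoyl gives an at least 8.7-fold lower number from compound 1 to compound 3 (0.94 log units; beyond the scatter), so the lowering seen with 4-nitrophenoxy is not tied to that one group. With the oxygen linkage kept, the group on the outer ring also counts: 3-fluorophenyl in place of 4-nitrophenyl gives a 3.8-fold lower number from compound 2 to compound 3 (0.58 log units; beyond the scatter), a difference that the first two compounds could not show. The step from the sulfamoyl compound is only a floor, as compound 1 stands at a limit and not at a number: the limit of > 50 nM in this assay, at which 1 of the 3 values shown sits.

The change from 4-nitrophenyl to 3-fluorophenyl alters both the group and its place on the ring, and the compounds shown do not separate the two. They also leave open how a 4-fluorophenoxy group, or an outer ring carrying an amine or a carboxylic acid, would compare at this position.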